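The source may hold more compounds than are shown below. What is called first, only, known or untested is meant among the compounds shown, and "the series" means these compounds.

Measured compounds and their values:

Compound 1 `N#Cc1ccc2c(Oc3ccc(F)cc3OCCn3ccc(=O)[nH]c3=O)cc(Cl)cc2c1` — in an ADME assay on MT2 cells (Homo sapiens) for cytotoxicity, read by MTT assay (on this read-out higher numbers stand for lower toxicity in this test and lower numbers for higher toxicity in this test), compound 1 gives 16000 nM
Compound 2 `N#Cc1cc2c(Oc3ccccc3OCCn3ccc(=O)[nH]c3=O)cc(F)cn2c1` — in this assay compound 2 gives 40000 nM
Compound 3 `Cc1ccc2c(Oc3ccccc3OCCn3ccc(=O)[nH]c3=O)cccc2c1` — in this assay compound 3 gives 40000 nM

Compound 3 stands level with compound 2 at the digits recorded, and together these two carry the highest numbers of the three; the difference between them lies within the scatter, so no order between compound 3 and compound 2 can be read from it. Compound 1 stands furthest from compound 3, with a number that is lower beyond the scatter.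

The next compound, compound 4 `O=c1ccn(CCOc2ccccc2Oc2cccc3ccccc23)c(=O)[nH]1`, is still to be measured in this assay. It differs from compound 3 in one place: hydrogen in place of methyl on an aromatic carbon. For the measured compounds named here, no step between measured compounds in this set matches such a change, so there is nothing to lean on for its size.

The account expects the step from compound 3 to compound 4 to be none beyond the scatter, as written in no change at the digits printed from compound 3 to compound 4 (within the scatter). The removal of a methyl is a small change, and compound 3 already sits at the top of the range seen here, so a number of about the same size is expected. For compound 4 in this assay the estimate is 40000 nM, with a range from 20000 nM to 80000 nM.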

Compound 4, half-maximal cytotoxic concentration: 80000 nM
Beside the measured number, compound 4's estimate is 2.0-fold (0.30 log units) below it; measured number inside the range.
By their numbers in this assay, from the lowest: compound 1; then compounds 2, 3 and 4 (each within the scatter of the next).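

In this assay this position gets its first reading, on an aromatic carbon that is meta to a fused ring and para to a fused ring: the exchange of methyl for hydrogen gives a 2.0-fold higher number from compound 3 to compound 4 (0.30 log units; within the scatter). This pair therefore gives no sign that the methyl counts for this read-out at this place, as the numbers with and without that one carbon cannot be told apart. Nothing available on these compounds offers an explanation for this result, so no cause can be given for it.

The compounds shown leave open whether a different group at this place, such as a methoxy group, an amine or a carboxylic acid, would move the number beyond the scatter, as a single exchange of methyl for hydrogen covers only a very small part of what could sit there. They also leave open whether the same exchange would read alike on a core bearing other substituents, such as the nitrile and the chlorine of compound 1.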